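This account rests on a few compounds, and the source may have more. Where it says the series, first, only, none or still open, it means among the compounds named here.

In a functional assay on the whole organism (artery, strain albino) with Rattus norvegicus as the target, with a stated time of 360 min, at a dose of 10 mg/kg by the oral route (a higher number here means more inhibition at the dose given (going by the name of the read-out), a lower number less inhibition), compound 1 `CC1=C(C(=O)Nc2ccc(F)cc2)C(c2ccc([N+](=O)[O-])cc2)N=C(SCc2ccccc2Cl)N1` gives 21.6%. Compound 2 `CC1=C(C(=O)Nc2ccc(F)cc2)C(c2ccc([N+](=O)[O-])cc2)N=C(SCc2cccc(Cl)c2)N1` differs from compound 1 in one place, (3-chlorophenyl in place of 2-chlorophenyl on a saturated chain carbon bound to a sulfur), and in this assay compound 2 gives 21.1%. The step is a number 0.5 percentage points lower from compound 1 to compound 2 (within the scatter). Compound 3 `CC1=C(C(=O)Nc2ccc(Br)cc2)C(c2ccc(Cl)cc2Cl)N=C(SCc2ccccc2Cl)N1` is built on another core; the difference between the two cores is not broken down here. In this assay compound 3 gives 38.1%, the highest of the three numbers, with compound 1 nearest and compound 2 furthest, both beyond the scatter. Compound 4 `CC1=C(C(=O)Nc2ccc(Br)cc2)C(c2ccc(Cl)cc2Cl)N=C(SCc2cccc(Cl)c2)N1` carries the same change as that from compound 1 to compound 2, now on the core of compound 3: 3-chlorophenyl in place of 2-chlorophenyl on a saturated chain carbon bound to a sulfur. The place of the change is the same in both pairs. Because a number 0.5 percentage points lower from compound 1 to compound 2 (within the scatter) stayed within the scatter, a step of about the same small size is expected here: a number 0.6 percentage points lower from compound 3 to compound 4 (within the scatter). Compound 4 is therefore estimated to give 37.5% in this assay, with the expected range running from 26% to 49%.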

Compound 4, a percentage reported as inhibition, in the whole organism at one dose (the size of the read-out at that dose, not a potency): 20.6%
Estimate against measurement, compound 4: 16.9 percentage points above; the measured number lies below the stated range.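

In this assay, 3-chlorophenyl in place of 2-chlorophenyl on a saturated chain carbon bound to a sulfur gives a number 17.5 percentage points lower from compound 3 to compound 4 (beyond the scatter), so the change did not carry over at the same size from the core of compound 1 to the core of compound 3: the same change on two cores in this assay, a number 0.5 percentage points lower (within the scatter) from compound 1 to compound 2 and a number 17.5 percentage points lower (beyond the scatter) from compound 3 to compound 4, 17 percentage points apart, beyond the scatter of two such steps This shows that, in these two pairs, the size of the step depends on the core that carries it, and that the small step on one core did not predict the step on the other. It does not show which part of the core matters, since the difference between the two cores is not broken down, nor why the steps differ, and two pairs give no rule for any other core.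

The compounds shown leave open how an unsubstituted benzyl, a methoxybenzyl or a longer chain such as phenylethyl on the sulfur would behave on either core. As far as these compounds go, it also remains open whether a core carrying an amine or a carboxylic acid would follow the core of compound 1 or that of compound 3.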